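A few compounds are considered here, and "the series" means these few. Any claim that something is new, unique, unknown or untested is made for them only; others in the source may bear on it.

Compound 1 `O=C(CN(c1ncnc2c1ncn2C1CCCCO1)C1CC1)NCC(=O)OCc1ccccc1` has been run in a functional assay on the whole organism (Tail, strain ICR) with Mus musculus as the target, in the tail flick test, with a stated time of 30 min, at a dose of 25 umol/kg by the oral route (a lower number here means a weaker effect, a higher number a stronger effect of the compound at the dose given), where compound 1 gives 55.7%. This is the highest of the three numbers in hand. Compound 2 `CC[C@H](C)[C@H](NC(=O)CN(c1nc(Cl)nc2[nH]cnc12)C1CC1)C(=O)O` gives 30.3% in this assay, and compound 3 `N=C(N)NCCC[C@H](NC(=O)CN(c1nc(Cl)nc2[nH]cnc12)C1CC1)C(=O)OCc1ccccc1` gives 23.2%; both lie below compound 1 by more than the scatter. Among the compounds with values here, no pair of measured compounds differs in one place only, so no single-point step is available for comparison. Compound 4 `C[C@H](NC(=O)CN(c1ncnc2c1ncn2C1CCCCO1)C1CC1)C(=O)OCc1ccccc1` is not yet measured; it differs from compound 1 by methyl in place of hydrogen on a saturated chain carbon bound to an amide-type nitrogen and a carbonyl carbon. In the absence of any measured step of this kind, the change is expected to be small, in neither direction beyond the scatter, and a number 5.7 percentage points lower from compound 1 to compound 4 (within the scatter) is the step expected. Compound 4 is accordingly estimated at 50%, with a range from 30% to 70%.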

Compound 4, a percentage reported as activity, at one dose (the size of the read-out at that dose, not a potency): 55.9%
For compound 4 the middle estimate is 5.9 percentage points below the measured one; the range from low to high includes it.
By their numbers in this assay, from the lowest: compounds 3 and 2 (each within the scatter of the next); then compounds 1 and 4 (each within the scatter of the next).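

Methyl in place of hydrogen on a saturated chain carbon bound to an amide-type nitrogen and a carbonyl carbon gives, in this assay, a number 0.2 percentage points higher from compound 1 to compound 4 (within the scatter), the first single-place step available in the series. At this dose, the read-out does not separate hydrogen from methyl at this position. No measurement in hand bears on the reason for this result.

On these data alone, whether this position also accepts an isopropyl group, a longer chain or a phenyl ring remains open. A carboxylic acid or an amine on this chain carbon is equally untested by the compounds shown.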